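The source may hold more compounds than are shown below. What is called first, only, known or untested is meant among the compounds shown, and "the series" means these compounds.

Measured so far:
Compound 1 `COc1cc(-n2c(-c3ccc([N+](=O)[O-])cc3)cn(C(C)=O)c2=O)cc(OC)c1OC` gives 7200 nM in a functional assay on HL-60 cells (Homo sapiens) for cytotoxicity, read by MTT assay, with a stated time of 48 h; a lower number here means a stronger inhibitor, a higher number a weaker inhibitor.
Compound 2 `COc1ccc(-c2cn(C(C)=O)c(=O)n2-c2cc(OC)c(OC)c(OC)c2)cc1` gives 5500 nM in this assay.
Compound 3 `COc1ccc(-c2cn(C(C)=O)c(=O)n2-c2cc(OC)c(OC)c(OC)c2)cc1OC` gives 12200 nM in this assay.

Compound 4 `COc1ccc(-c2cn(C(C)=O)c(=O)n2-c2cc(OC)c(OC)c(OC)c2)cc1[N+](=O)[O-]` has not been measured. It arises from compound 3 by one change, (nitro in place of methoxy on an aromatic carbon). A change of the same kind was made from compound 2 to compound 1, (nitro in place of methoxy on an aromatic carbon), and made the step of a 1.3-fold higher number from compound 2 to compound 1 (0.12 log units; within the scatter). The two changes are not the same. In compound 1 the new group sits para to a large group, whereas in compound 4 it sits ortho to a methoxy group and meta to a large group. The two cores differ by methoxy in place of hydrogen on an aromatic carbon, which made the step of a 2.2-fold higher number from compound 2 to compound 3 (0.35 log units; beyond the scatter).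

The expected step is a 1.1-fold higher number from compound 3 to compound 4 (0.06 log units; within the scatter), for this assay. This expectation rests on the earlier step of the same kind, which read a 1.3-fold higher number from compound 2 to compound 1 (0.12 log units; within the scatter). Compound 4 is therefore expected to give about 14000 nM in this assay. Compound 4 is expected to fall between 6000 nM and 32000 nM.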

Compound 4, half-maximal inhibitory concentration: 5600 nM
The estimate for compound 4 lay 2.5-fold (0.40 log units) above the measured number, outside the stated range (below it).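

Putting nitro in place of methoxy did not do the same thing on both cores in this assay: the same change on two cores in this assay, a 1.3-fold higher number (0.12 log units; within the scatter) from compound 2 to compound 1 and a 2.2-fold lower number (0.34 log units; beyond the scatter) from compound 3 to compound 4, 2.9-fold (0.46 log units) apart, beyond the scatter of two such steps On the core of compound 3, where the nitro group sits ortho to a methoxy group, the swap gives a 2.2-fold lower number from compound 3 to compound 4 (0.34 log units; beyond the scatter), while nitro in place of hydrogen gives a 1.0-fold higher number from compound 2 to compound 4 (0.01 log units; within the scatter). Going by these compounds alone, this shows that the step seen on one core cannot simply be copied to the other, but with only two such pairs, which also differ in where the swap sits on the ring, it does not show why they part or give a rule for other cores.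

The compounds shown leave open what other groups would do at this same place on the ring, for example an amine or a carboxylic acid. They also leave open whether a nitro group placed ortho to a methoxy group would behave as it does in compound 4 on any other core.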